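The source may report more compounds than this note shows. Statements on the series, on what has been measured and on what is new or still open speak of the compounds shown alone.

Working notes on the series, read in a functional assay on A549 cells (Homo sapiens) for antiproliferative activity, read by MTT assay; on this read-out higher numbers stand for weaker inhibition and lower numbers for stronger inhibition. Compound 1 `Cn1c(=O)c(=O)n(C2CCCC2)c2nc(N/N=C/c3ccccc3)ncc21` gives > 100000 nM, which is a limit and not a number. For the measured compounds named here, compound 2 `Cn1c(=O)c(=O)n(C2CCCC2)c2nc(N/N=C/c3ccc(Cl)cc3)ncc21` gives 6890 nM, the only actual number so far. Going by the values given here, the single measured step, an at least 14-fold lower number from compound 1 to compound 2 (1.16 log units; beyond the scatter), is large and beyond the scatter; it is chloro in place of hydrogen on an aromatic carbon. Its size is bounded by the limit of > 100000 nM in this assay, at which 1 of the 2 values shown sits, so the true step could be larger.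

Next is compound 3 `Cn1c(=O)c(=O)n(C2CCCC2)c2nc(N/N=C/c3ccc(O)c(F)c3)ncc21`. The change is 3-fluoro-4-hydroxyphenyl in place of 4-chlorophenyl on a carbon with a double bond to nitrogen. Compound 3 has no chloro, so the gain in an at least 14-fold lower number from compound 1 to compound 2 (1.16 log units; beyond the scatter) may be partly lost, although the ring is again substituted. Among the compounds with values here, that step is the only guide, and it covers neither the fluoro nor the hydroxy group. A moderate move towards weaker inhibition is therefore expected, with the estimated step being a 2.6-fold higher number from compound 2 to compound 3 (0.42 log units; beyond the scatter). For compound 3 the estimate is 18000 nM, with an expected range from 4000 nM to 80000 nM.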

Compound 3, half-maximal inhibitory concentration: 97800 nM
Beside the measured number, compound 3's estimate is 5.4-fold (0.74 log units) below it, outside the stated range (above it).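

In this assay this position, on a carbon with a double bond to nitrogen, proves sensitive to which substituents the phenyl ring carries: 3-fluoro-4-hydroxyphenyl in place of 4-chlorophenyl gives a 14-fold higher number from compound 2 to compound 3 (1.15 log units; beyond the scatter). Set against an at least 14-fold lower number from compound 1 to compound 2 (1.16 log units; beyond the scatter), this shows that a substituted ring alone does not keep the number of compound 2, and among the three compounds only the 4-chlorophenyl of compound 2 stands clear of the weak end of the range. The remaining step, an at least 1.0-fold lower number from compound 1 to compound 3 (0.00 log units; that floor lies within the scatter), cannot be read as a gain or a loss, because compound 1 carries a limit and not a number: the limit of > 100000 nM in this assay, at which 1 of the 3 values shown sits.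

The fluoro and hydroxy groups enter together in compound 3, so the compounds shown do not tell which of the two, or the absence of chloro, accounts for the step from the 4-chlorophenyl ring. Also open, on these data alone, is whether chloro itself matters at this ring or whether a bromo group, a methoxy group or an amine on the ring would give a similar number in this assay.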